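The source may report more compounds than this note shows. Statements on the series, on what has been measured and on what is new or still open speak of the compounds shown alone.

Compound 1 `C(=C\C1CCCN(CCCCc2ccccc2)C1)\c1ccccc1`: 7 nM
Compound 2 `C(=C\C1CCCN(CCCOc2ccccc2)C1)\c1ccccc1`: 15 nM

In an assay on isolated protein for binding affinity to Sigma non-opioid intracellular receptor 1 (Rattus norvegicus) (on this read-out lower numbers stand for stronger inhibition and higher numbers for weaker inhibition), compound 2 gives 15 nM, the highest of the two numbers; its nearest neighbour is compound 1 with 7 nM. Going by the values given here, the one measured step at this position, a 2.1-fold higher number from compound 1 to compound 2 (0.33 log units; beyond the scatter), was modest. Compound 3 `O=C(CCCN1CCCC(/C=C\c2ccccc2)C1)c1ccccc1` differs from compound 2 by benzoyl in place of phenoxy on a saturated chain carbon, three bonds along the chain from an amine nitrogen in a ring. That step concerns a different exchange at the same place, so it gives only a rough guide; a change of comparable modest size in either direction, or none beyond the scatter, is expected in this assay. Compound 3 is therefore estimated at 20 nM (range 8 nM to 50 nM), meaning a 1.3-fold higher number from compound 2 to compound 3 (0.12 log units; within the scatter).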

Compound 3, half-maximal inhibitory concentration: 15 nM
For compound 3 the middle estimate is 1.3-fold (0.12 log units) above the measured one, within the range that was stated.
By their numbers in this assay, from the lowest: compound 1; then compounds 2 and 3 (each within the scatter of the next).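

In this assay the exchange of phenoxy for benzoyl, on a saturated chain carbon, three bonds along the chain from an amine nitrogen in a ring, gives no change at the digits printed from compound 2 to compound 3 (within the scatter) and so adds a second group that sits level with phenoxy here. Benzoyl in place of benzyl gives a 2.1-fold higher number from compound 1 to compound 3 (0.33 log units; beyond the scatter) and matches the step already seen for phenoxy, which leaves compound 1 apart from both. Nothing available explains these results. As far as these compounds go, whether an amine, a carboxylic acid or a longer chain at this place would stay level with these groups remains open.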